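The compounds below may be only part of what the source reports. "The series", "measured", "known", "first", "only" and "open" are said of these compounds alone.

Compounds measured in an ADME assay on MT4 cells (Homo sapiens) for cytotoxicity, read by MTT assay, with a stated time of 5 days; on this read-out lower numbers stand for higher toxicity in this test and higher numbers for lower toxicity in this test:

Compound 1, `Cc1cc(C)c(Oc2cc(Nc3ccc(C#N)cc3)ncc2C(=O)NCc2cn(Cc3ccccc3F)nn2)c(C)c1`, reaches only the limit of the test and gives > 222000 nM.
Compound 2, `Cc1cc(C)c(Oc2cc(Nc3ccc(C#N)cc3)ncc2C(=O)NCc2cn(Cc3ccccc3C#N)nn2)c(C)c1`, likewise reaches only the limit and gives > 219000 nM.
Compound 3, `Cc1cc(C)c(Oc2cc(Nc3ccc(C#N)cc3)ncc2C(=O)NCc2cn(Cc3ccc(F)cc3)nn2)c(C)c1`, also reaches only the limit and gives >= 153000 nM.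

Going by the values given here, compound 3 therefore stands where the other two stand: none of the three gives a number, each only a limit, so no compound can be placed above or below another. The unmeasured compound 4 is `Cc1cc(C)c(Oc2cc(Nc3ccc(C#N)cc3)ncc2C(=O)NCc2cn(Cc3ccccc3C)nn2)c(C)c1`. It differs from compound 3 in one place: 2-methylphenyl in place of 4-fluorophenyl on a saturated chain carbon bound to an aromatic nitrogen.

Among the compounds with values here, three measured steps concern changes at this same place, a saturated chain carbon bound to an aromatic nitrogen. The step that the two limits leave unreadable from compound 1 to compound 2, the step that the two limits leave unreadable from compound 1 to compound 3 and the step that the two limits leave unreadable from compound 2 to compound 3 are all unreadable in size, because each end is a limit (the limit of > 219000 nM in this assay, at which 1 of the 3 values shown sits), (the limit of > 222000 nM in this assay, at which 1 of the 3 values shown sits), (the limit of >= 153000 nM in this assay, at which 1 of the 3 values shown sits). They show only that swapping fluoro for cyano, or moving a fluoro from one position of the benzyl ring to another, left every compound beyond the reach of this assay.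

For compound 4 the expectation is the same: no step beyond the scatter, with the estimated step that the limit leaves unreadable from compound 3 to compound 4, and an estimated value of 200000 nM, ranging from 100000 nM to 300000 nM, most likely reported again as a limit.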

Compound 4, half-maximal cytotoxic concentration: >= 164000 nM
Compound 4: only a limit was reported; the forecaster's own chance of this, stated with the estimate: 85%; the middle value does not contradict the limit.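

Compound 4 gives only a limit, so its steps to compound 1, compound 2 and compound 3 cannot be read, because both ends of each step are limits: the limit of >= 164000 nM in this assay, at which 1 of the 4 values shown sits. The compounds shown leave open at what concentration any of the four would become toxic in this assay, and whether a change at this place shifts that concentration.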